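Closing a Side-Chain Amine into a Ring

The source may hold more compounds than are shown below. What is called first, only, known or untested is meant among the compounds shown, and "the series" means these compounds.

Of the compounds shown here, two built on a shared core have been measured so far. Compound 1, `CCN(CC)CCNc1cc(C)c2cc(NC(=O)c3ccc(Cl)c(Cl)c3)ccc2n1`, and compound 2, `CCN1CCN(c2cc(C)c3cc(NC(=O)c4ccc5ccccc5n4)ccc3n2)CC1`, were both tested in a functional assay on MCF7 cells (Homo sapiens) for antiproliferative activity, read by MTT assay, with a stated time of 72 h; on this read-out lower numbers stand for stronger inhibition and higher numbers for weaker inhibition. In this assay compound 1 gives 1420 nM, while compound 2 gives 7060 nM. Compound 1 therefore holds the lower of the two numbers, and its gap to compound 2 lies beyond the usual scatter of repeated measurements.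

The next compound, compound 3, `Cc1cc(NCCN2CCCC2)nc2ccc(NC(=O)c3ccc(Cl)c(Cl)c3)cc12`, is not yet measured. It differs from compound 1 in one place: pyrrolidin-1-yl in place of diethylamino on a saturated chain carbon, two bonds along the chain from a nitrogen on an aromatic ring. The two groups that are swapped match in their counts of heavy atoms and hydrogen-bond acceptors; the incoming group simply joins its carbons into a five-membered non-aromatic ring.

For the measured compounds named here, no measured pair shows this kind of change, so its effect cannot be read from the numbers in hand. Because compound 1 gives 1420 nM and the swap leaves the counts unchanged, only a small movement is expected. The expected step is a 1.2-fold lower number from compound 1 to compound 3 (0.07 log units; within the scatter), within the scatter in either direction. Compound 3 is estimated at 1200 nM, with a likely range from 400 nM to 3600 nM.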

Compound 3, half-maximal inhibitory concentration in the MCF7 assay: 1280 nM
Compound 3: middle estimate off by 1.1-fold (0.03 log units), on the low side, within the range that was stated.
By their numbers in the MCF7 assay, from the lowest: compounds 3 and 1 (each within the scatter of the next); then compound 2.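

In the MCF7 assay, joining the two ethyl arms of the diethylamino group into a pyrrolidin-1-yl ring gives a 1.1-fold lower number from compound 1 to compound 3 (0.05 log units; within the scatter), the first step read at this place on the saturated chain, and it shows that a ring and an open amine can stand here with no change beyond the scatter. The same holds for a second property: in a physicochemical assay for solubility (a lower number here means a less soluble compound, a higher number a more soluble compound), compound 1 gives 95.2 ug/mL and compound 3 gives 84.5 ug/mL, two values within the usual scatter of each other. Nothing measured here offers an explanation for how closely the open and the closed amine match.

On these data alone, whether the match would extend to other rings on this chain, such as piperidin-1-yl or morpholin-4-yl, or to a longer chain carrying the same pyrrolidin-1-yl group, stays open. Compound 2 differs from compound 1 and compound 3 in more than one place, so its number cannot be used to judge the side chain alone.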